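The source may report more compounds than this note shows. Statements on the series, on what has been measured and on what is new or still open speak of the compounds shown alone.

Measured so far in a functional assay on A549 cells (Homo sapiens) for inhibition, read by sulforhodamine B assay, with a stated time of 48 h; a higher number here means a weaker inhibitor of growth, a lower number a stronger inhibitor of growth:
compound 1, `Cc1cc(O)cc(-c2nn(CC#N)cc2-c2ccnc(-c3ccc(Oc4ccccc4)cc3)c2)c1`: 2000 nM
compound 2, `COc1cc(C)cc(-c2nn(CC#N)cc2-c2ccnc(-c3ccc(N(C)C)cc3)c2)c1`: 583 nM

Compound 2 holds the lowest of the two numbers; the nearest is compound 1, whose number is higher by a margin beyond the scatter. The two differ in more than one place, so that pair shows only this much. Compound 3, `Cc1cc(O)cc(-c2nn(CC#N)cc2-c2ccnc(-c3ccc(N(C)C)cc3)c2)c1`, is not yet measured in this assay. It differs from compound 2 in one place: hydrogen in place of methyl on an oxygen on an aromatic ring. Within the data shown here, no measured pair in this set isolates that change; compound 1 also carries the hydroxy, but differs from compound 3 elsewhere as well, so it gives no clean reading. Among the measured compounds shown here, with no step to lean on, the expectation is a step of small size, toward a somewhat higher number or none beyond the scatter, taken as a 1.4-fold higher number from compound 2 to compound 3 (0.14 log units; within the scatter). Compound 3 is accordingly estimated at 800 nM, with a range from 300 nM to 2500 nM.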

Compound 3, concentration for 50% growth inhibition: 4180 nM
Compound 3: the middle estimate sits 5.2-fold (0.72 log units) below what was measured; measured number outside the range, above it.
By their numbers in this assay, from the lowest: compound 2; then compound 1; then compound 3.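

In this assay, among these compounds, going from methoxy to hydroxy on the aromatic ring gives a 7.2-fold higher number from compound 2 to compound 3 (0.86 log units; beyond the scatter) as the first clean reading of this change, so the methyl on that oxygen matters, at least with dimethylamino held constant. With the hydroxy held constant, dimethylamino in place of phenoxy gives a 2.1-fold higher number from compound 1 to compound 3 (0.32 log units; beyond the scatter) and so the second place also moves the number, with phenoxy on the lower side in this pair. No measurement here offers an explanation for either step.

On these data alone, whether the phenoxy and dimethylamino groups keep this order with methoxy in place of hydroxy remains open. Also open, as far as these compounds go, is whether ethoxy, a longer alkoxy chain or an amine on that aromatic carbon would keep the number of compound 2 583 nM or raise it.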